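Fluorine removed from compound 1: a step without precedent

This account rests on a few compounds, and the source may have more. Where it says the series, first, only, none or still open, it means among the compounds named here.

Among the compounds with values here, compound 1 `Fc1ccc(Oc2ccc(/C=N/NC(=S)Nc3ccc(Cl)cc3)cc2)cc1` is one of three compounds measured in a physicochemical assay for lipophilicity, in phosphate buffer, measured as octanol-water partition, with a stated time of 24 h (on this read-out lower numbers stand for lower lipophilicity and higher numbers for higher lipophilicity), where compound 1 gives 5.84. Compound 3 `Fc1ccc(Oc2ccc(/C=N/NC(=S)Nc3ccc(Br)cc3)cc2)cc1` gives 5.82 and compound 2 `S=C(N/N=C/c1ccc(Oc2ccc(Br)cc2)cc1)Nc1ccccc1` gives 5.62; both lie within the scatter of compound 1, so no order among the three can be read. Within the data shown here, the only measured single-point step, a number 0.02 log units lower from compound 1 to compound 3 (within the scatter), concerns bromo in place of chloro and does not bear on the change followed here. Compound 4 `S=C(N/N=C/c1ccc(Oc2ccccc2)cc1)Nc1ccc(Cl)cc1` differs from compound 1 by hydrogen in place of fluoro on an aromatic carbon. Among the measured compounds shown here, no measured step covers this change, so the expectation rests on the change alone: a small downward step is expected, a number 0.14 log units lower from compound 1 to compound 4 (within the scatter), within the scatter. Compound 4 is estimated at 5.7, between 5.45 and 5.95.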

Compound 4, partition coefficient: 5.64
The estimate for compound 4 lay 0.06 log units above the measured number, and the stated range covers the measured number.
By their numbers in this assay, from the lowest: compounds 2, 4, 3 and 1 (each within the scatter of the next).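

The 4-fluorophenoxy to phenoxy change now has a measured step of its own in this assay (a number 0.20 log units lower from compound 1 to compound 4 (within the scatter)), the only one at this position. At this aromatic carbon, para to a large group, hydrogen and fluoro therefore cannot be told apart on this read-out, with the rest of compound 1 unchanged. No supporting measurement bears on this result.

Open, as far as these compounds go, is what an amine or a carboxylic acid at this position would give in this assay. Also open, from the compounds shown here alone, is whether the same change would give a similar step with bromo in place of chloro.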